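Aryl replacement at the quinoline-free core: permeability outlook

A few compounds are considered here, and "the series" means these few. Any claim that something is new, unique, unknown or untested is made for them only; others in the source may bear on it.

Series notes. Compound 1 `COc1ccc(F)cc1CNCCCNc1ccnc2cc(CC(C)C)ccc12` carries an isobutyl group on the bicyclic core; in an ADME assay for permeability, using PAMPA, with a stated time of 30 min, at pH 7.4 (on this read-out higher numbers stand for higher permeability and lower numbers for lower permeability), compound 1 gives 23 10^-6 cm/s. Compound 2 `COc1ccc(F)cc1CNCCCNc1ccnc2cc(-c3cccc4ccccc34)ccc12` carries a naphthalen-1-yl group at the same carbon; in this assay compound 2 gives 237 10^-6 cm/s. Within the data shown here, the one measured step, a 10-fold higher number from compound 1 to compound 2 (1.01 log units; beyond the scatter), is the only comparison available, and compound 2 stands highest of the two numbers.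

Compound 3 `COc1ccc(F)cc1CNCCCNc1ccnc2cc(Oc3ccccc3OC)ccc12` differs from compound 2 by 2-methoxyphenoxy in place of naphthalen-1-yl on an aromatic carbon.

Among the measured compounds shown here, no measured step involves a 2-methoxyphenoxy group, so the step from compound 2 to compound 3 has no direct precedent. For the measured compounds named here, the only step that bears on it indirectly is the one from compound 1 to compound 2, which shows how far the naphthalen-1-yl group carried the number upward relative to isobutyl. Removing that group is therefore expected to move this assay downward, by a step of moderate size rather than the full span of the measured step. The estimated step is a 3.4-fold lower number from compound 2 to compound 3 (0.53 log units; beyond the scatter). Compound 3 is expected to give about 70 10^-6 cm/s, within a range from 25 10^-6 cm/s to 200 10^-6 cm/s.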

Compound 3, apparent permeability in the ADME assay: 317 10^-6 cm/s
Estimate against measurement, compound 3: 4.5-fold (0.66 log units) below; measured number above the stated range.
By their numbers in the ADME assay, from the lowest: compound 1; then compounds 2 and 3 (each within the scatter of the next).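

In the ADME assay the change gives a 1.3-fold higher number from compound 2 to compound 3 (0.13 log units; within the scatter), so at this aromatic carbon 2-methoxyphenoxy, with one six-membered aromatic ring of carbon only and 2 hydrogen-bond acceptors, cannot be told apart from naphthalen-1-yl, with 2 six-membered aromatic rings of carbon only and 0 hydrogen-bond acceptors. The high number is therefore not tied to naphthalen-1-yl alone, as the ADME assay also gives a 14-fold higher number from compound 1 to compound 3 (1.14 log units; beyond the scatter) and both aromatic groups now stand clear of isobutyl. In a physicochemical assay for acid dissociation, compound 2 gives 9.47 and compound 3 gives 9.28, the same exchange gives a number 0.19 log units lower from compound 2 to compound 3 (within the scatter), and nothing measured here accounts for the level shared by compound 2 and compound 3.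

The compounds shown do not separate the contributions of the oxygen link and the methoxy group within 2-methoxyphenoxy, which a plain phenyl or an unsubstituted phenoxy group at this carbon would begin to do. Also open, going by these compounds, is whether a group of a different kind at this carbon, such as a carboxylic acid or a morpholine, would stay with compound 2 and compound 3 in the ADME assay or fall back towards compound 1.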